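A few compounds are considered here, and "the series" means these few. Any claim that something is new, unique, unknown or untested is made for them only; others in the source may bear on it.

Measured compounds:
- compound 1 `CC1CCCCC1C(=O)N1CC(c2nc(-c3cccc(F)c3)no2)C1` — an assay on HEK293 cells for positive allosteric modulation of metabotropic glutamate receptor 5 (Homo sapiens), read by FLIPR; a higher number here means that more compound is needed for the effect, a lower number that less compound is needed: 540 nM
- compound 2 `O=C(c1ccc(F)cc1)N1CC(c2nc(-c3cccc(Cl)c3)no2)C1` — this assay: > 10000 nM (a limit of this assay, not a number)
- compound 3 `Cc1ccc(C(=O)N2CC(c3nc(-c4cccc(F)c4)no3)C2)cc1` — this assay: 6800 nM

Compound 3 holds the highest of the two numbers that are numbers; its nearest neighbour is compound 1, with a 13-fold higher number from compound 1 to compound 3 (1.10 log units; beyond the scatter). The value of compound 2 is a limit only (the limit of > 10000 nM in this assay, at which 1 of the 3 values shown sits).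

Compound 4 `O=C(c1ccc(F)cc1)N1CC(c2nc(-c3cccc(F)c3)no2)C1` is not yet measured. It differs from compound 3 by fluoro in place of methyl on an aromatic carbon. Going by the values given here, no measured step covers this exchange: the one measured step, from compound 1 to compound 3, changes the group on the carbonyl carbon altogether, not a substituent on an aryl ring. Compound 2 carries the same 4-fluorophenyl amide as compound 4 but a 3-chlorophenyl on the oxadiazole, and it reached only the limit; compound 3, with the 4-methylphenyl amide, sits within the measurable range. Taken together these points give no direction beyond the scatter for the methyl-to-fluoro swap itself, but they place compound 4 among the weak members. The expectation is therefore a step of a 1.3-fold higher number from compound 3 to compound 4 (0.12 log units; within the scatter), with a sizeable chance that compound 4 also reports a limit. The estimate for compound 4 in this assay is 9000 nM, within 3000 nM to 30000 nM.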

Compound 4, half-maximal effective concentration: 2400 nM
Estimate against measurement, compound 4: 3.8-fold (0.57 log units) above, outside the stated range (below it).
By their numbers in this assay, from the lowest: compound 1; then compound 4; then compound 3. At a limit, above all of these: compound 2.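

Going by these compounds alone, on the aromatic carbon para to a large group, the exchange of 4-methylphenyl for 4-fluorophenyl is the first change of an aryl substituent that can be read in this assay, and it gives a 2.8-fold lower number from compound 3 to compound 4 (0.45 log units; beyond the scatter) on the amide side. On the other aryl group, fluoro in place of chloro gives an at least 4.1-fold lower number from compound 2 to compound 4 (0.61 log units; beyond the scatter) as a lower bound only, since compound 2 stands at a limit and not at a number: the limit of > 10000 nM in this assay, at which 1 of the 4 values shown sits. The 4-fluorophenyl amide narrows the gap to the 2-methylcyclohexyl amide but does not close it, with a 4.4-fold higher number from compound 1 to compound 4 (0.65 log units; beyond the scatter) remaining.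

Two substituents at this position give no trend, so a methoxy, a nitrile or an unsubstituted phenyl would be needed to show one. A plain cyclohexyl or a 2-methylphenyl amide would separate the effect of the ring from that of the methyl group in compound 1 .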